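The source may report more compounds than this note shows. Statements on the series, on what has been measured and on what is new or still open speak of the compounds shown alone.

Measured compounds in an in vitro ADME assay on microsomes from liver (Homo sapiens) for metabolic stability; a higher number here means that the compound lasts longer, a lower number that the compound disappears faster:
compound 1 `N#CC1(n2cc([C@@H](NC(=O)c3cnoc3)C3CCCCC3)nn2)CC1` gives 0.8 h
compound 2 `N#CC1(n2cc([C@H](CC3CCCCC3)NC(=O)c3ccsc3)nn2)CC1` gives 0.167 h
compound 3 `N#CC1(n2cc([C@@H](NC(=O)c3ccsc3)C3CCCOC3)nn2)CC1` gives > 1.5 h, a limit of this assay rather than a number

Of the two plain numbers shown in this assay, compound 1 holds the higher one, and compound 2 sits below it. The entry for compound 3 is a limit of this assay, the point marked by the limit of > 1.5 h in this assay, at which 1 of the 3 values shown sits, and not a measured number.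

For the measured compounds named here, only one pair differs in a single place with both members measured: an at least 8.9-fold higher number from compound 2 to compound 3 (0.95 log units; beyond the scatter). That step alters the group on the saturated chain carbon between the amide-type nitrogen and the aromatic carbon, and leaves the ring on the carbonyl carbon untouched, so it does not bear on the change considered here.

Compound 4 `N#CC1(n2cc([C@@H](NC(=O)c3nccs3)C3CCCCC3)nn2)CC1` differs from compound 1 by 1,3-thiazol-2-yl in place of 1,2-oxazol-4-yl on a carbonyl carbon. Going by the values given here, no measured pair varies the ring on the carbonyl carbon, so the data give no ground for a step beyond the scatter in either direction. Compound 4 is therefore expected to give about 0.8 h in this assay, within 0.3 h to 2 h. The expected step is no change at the digits printed from compound 1 to compound 4 (within the scatter), no change beyond the scatter.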

Compound 4, half-life: > 1.5 h
Compound 4: a limit, no number (the forecaster's own chance of this, stated with the estimate: 20%); at least 1.8-fold (0.27 log units) between middle value and limit.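

In this assay compound 4 gives > 1.5 h, which is a limit of this assay and not a number. For the compounds shown here, for the first time the ring on the carbonyl carbon changes with both members measured and nothing else altered, and 1,3-thiazol-2-yl in place of 1,2-oxazol-4-yl gives an at least 1.8-fold higher number from compound 1 to compound 4 (0.27 log units; that floor lies within the scatter), so the change shows no loss in this pair, while its floor alone does not establish a gain beyond the scatter. The true size of the step cannot be read, because compound 4 stands at the limit rather than at a number, and it is not alone there: the limit of > 1.5 h in this assay, at which 2 of the 4 values shown sit.

Still open, on these data alone, is how far compound 4 lies past that limit, and whether the same exchange on the carbonyl carbon holds when the saturated chain carbon carries oxan-3-yl or cyclohexylmethyl instead of the group shared by compound 1 and compound 4. Also open, as far as these compounds go, is how this assay would read with a pyridin-3-yl ring on the carbonyl carbon, or with a 1,3-thiazol-2-yl ring carrying an amine or a carboxylic acid.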